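From 4-chlorophenyl to 3,4-dichlorophenyl in compound 2

The compounds below may be only part of what the source reports. "The series", "measured", "known", "first", "only" and "open" are said of these compounds alone.

Three related compounds have been measured so far. In a functional assay on HL-60 cells (Homo sapiens) for antiproliferative activity, read by MTT assay, with a stated time of 72 h (on this read-out higher numbers stand for weaker inhibition and lower numbers for stronger inhibition), compound 1 (`CC(C)(C)c1ccc(OCCCON2C(N)=NC(N)=NC23CCSCC3)cc1`) gives 280 nM as its result, compound 2 (`NC1=NC2(CCOCC2)N(OCCCOc2ccc(Cl)cc2)C(N)=N1`) gives 330 nM and compound 3 (`NC1=NC2(CCSCC2)N(OCCCOc2cc(Cl)c(Cl)cc2Cl)C(N)=N1`) gives 730 nM on the same scale. Compound 2 and compound 1 lie within the scatter of each other, so they cannot be ranked, while compound 3 has a clearly higher number than compound 2, which means weaker inhibition.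

Compound 4 (`NC1=NC2(CCOCC2)N(OCCCOc2ccc(Cl)c(Cl)c2)C(N)=N1`) has not been measured yet. It is compound 2 with a single change (chloro in place of hydrogen on an aromatic carbon): chloro in place of hydrogen on an aromatic carbon, which turns 4-chlorophenyl into 3,4-dichlorophenyl. Among the measured compounds shown here, no two measured compounds differ in one place only, so nothing here measures this change directly. The nearest hint is compound 3 with 730 nM as its result, which also carries more than one chloro group but differs from compound 2 elsewhere too, so it is weak evidence.

In this assay a step within the scatter is expected, with no firm direction. The estimated step of a 1.1-fold lower number from compound 2 to compound 4 (0.04 log units; within the scatter) is therefore small. For compound 4 the estimated value is 300 nM within a range from 120 nM to 750 nM on this read-out.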

Compound 4, half-maximal inhibitory concentration: 1240 nM
The estimate for compound 4 lay 4.1-fold (0.62 log units) below the measured number; measured number outside the range, above it.
By their numbers in this assay, from the lowest: compounds 1 and 2 (each within the scatter of the next); then compounds 3 and 4 (each within the scatter of the next).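

In this assay, adding one chloro group to the aromatic ring, ortho to the chloro group already there, gives a 3.8-fold higher number from compound 2 to compound 4 (0.57 log units; beyond the scatter), and a higher number here means weaker inhibition. The earlier compounds shown here differed from one another in more than one place, so they could not isolate any single change; this pair shows that this position on the ring is not indifferent, since one added heavy atom moves the result beyond the usual scatter. The data offer no measurement that explains why this change weakens inhibition.

This single pair cannot tell whether the loss belongs to chloro itself or would also appear with another group at this position, such as fluoro, methyl or methoxy. It also leaves open whether the same change from 4-chlorophenyl to 3,4-dichlorophenyl would give a step of similar size on the core of compound 1, whose other parts differ from those of compound 2.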